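The source may hold more compounds than are shown below. What is called first, only, known or untested is meant among the compounds shown, and "the series" means these compounds.

Measured so far:
Compound 1, `C/C(=C\Cc1ccc(=O)c(O)cc1C(C)C)CO`: 29%
Compound 2, `C/C(=C\CC1=C[C@H]2C(=O)C(O)=C[C@@]12C(C)C)CO`: 29%

Both were tested in a functional assay on HepG2 cells (Homo sapiens) for inhibition, with a stated time of 24 h, tested at 20 uM; on this read-out lower numbers stand for less inhibition and higher numbers for more inhibition at the one concentration tested (going by the name of the read-out). Compound 2 gives 29%, and compound 1 gives 29%; these two values lie within the scatter of each other, so no order can be read from them. Compound 3, `C/C(=C\CC1=C[C@@H]2C(=O)C(O)=C[C@]12C(C)C)CO`, has not yet been measured. Compared with compound 2 the change is: the two compounds have the same atoms and bonds and differ only in configuration as drawn: 2 of 3 stereo elements differ; a stereocentre at a saturated ring carbon is drawn R in compound 2 and S in compound 3; a stereocentre at a saturated ring carbon is drawn R in compound 2 and S in compound 3. Nothing measured here shows how a change in configuration alone moves the read-out. For compound 3 only a step within the scatter is expected: no change at the digits printed from compound 2 to compound 3 (within the scatter). Compound 3 is estimated at 29%, with a range from 12% to 48%.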

Compound 3, a percentage reported as inhibition, at one concentration (the size of the read-out at that concentration, not a potency): 29%
For compound 3 middle estimate and measured number coincide at the digits printed; measured number inside the range.
By their numbers in this assay, from the lowest: compounds 1, 2 and 3 (each within the scatter of the next).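

In this assay, changing both ring stereocentres from R to S gives no change at the digits printed from compound 2 to compound 3 (within the scatter). Nothing earlier tested configuration alone, and this pair can be read as such a test because of one fact: the fact that compounds 2 and 3 differ only in the configuration as drawn. At this single concentration, the read-out therefore does not separate the two drawn configurations.

As far as these compounds go, it remains open what changing only one of these stereocentres would do, and whether the two compounds would stay level at other concentrations. From the compounds shown here alone, the effect of replacing the side-chain alcohol with an amine or a carboxylic acid is also open.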